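Halogen substituents and agonist read-out in the shared core

A few compounds are considered here, and "the series" means these few. Any claim that something is new, unique, unknown or untested is made for them only; others in the source may bear on it.

For the measured compounds named here, compound 3 `Nc1scc(-c2ccccc2)c1C(=O)c1ccc(Cl)cc1` stands second highest of the three numbers so far: in a functional assay on CHO cells for agonist activity at adenosine receptor A1 (Homo sapiens), read by fluorescence and ERK phosphorylation, with stated times of 30 min and 1.5 h, tested at 10 uM (a lower number here means a weaker effect, a higher number a stronger effect of the compound at the concentration tested), compound 3 gives 64%, while compound 2 `Nc1scc(-c2cccc(Br)c2)c1C(=O)c1ccccc1` gives 76% and compound 1 `Nc1scc(-c2ccccc2)c1C(=O)c1ccccc1` gives 48%. Compound 4 `Nc1scc(-c2ccc(I)cc2)c1C(=O)c1ccc(Cl)cc1` differs from compound 3 in one place: iodo in place of hydrogen on an aromatic carbon. Going by the values given here, two measured steps bear on this change. A halogen entering the same ring as here gave a number 28 percentage points higher from compound 1 to compound 2 (beyond the scatter); a halogen entering the other ring gave a number 16 percentage points higher from compound 1 to compound 3 (beyond the scatter). Both steps ran upward beyond the scatter, so an upward step is expected here as well, of a size between those two, a number 20 percentage points higher from compound 3 to compound 4 (beyond the scatter). Compound 4 is therefore estimated at 84% in this assay, within a range from 66% to 100%.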

Compound 4, a percentage reported as activity, at one concentration (the size of the read-out at that concentration, not a potency): 61%
For compound 4 the middle estimate is 23 percentage points above the measured one; the whole stated range lies above it.
By their numbers in this assay, from the lowest: compound 1; then compounds 4 and 3 (each within the scatter of the next); then compound 2.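

In this assay, for the compounds shown here, iodo on an aromatic carbon, para to a large group, gives a number 3 percentage points lower from compound 3 to compound 4 (within the scatter), the first halogen step that does not lie beyond the scatter. A halogen added to the shared core therefore does not raise the read-out in every case, and compound 4 goes against the upward pattern of the two earlier steps, both of which started from compound 1. Nothing available explains this flat step.

The compounds shown do not separate the effect of iodo from that of its place or of the chloro already present in compound 3. On these data alone, whether an amine or a carboxylic acid at this place would shift the read-out stays open.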